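The source may hold more compounds than are shown below. What is called first, only, known or untested is meant among the compounds shown, and "the series" means these compounds.

Three compounds share one core and differ only in the group carried on one aromatic carbon. Compound 1 `Brc1cn2ccnc2c(-c2ccc3ncn(C4CCCCC4)c3c2)n1` carries bromo there, and in a functional assay on MDA-MB-468 cells (Homo sapiens) for inhibition, read by sulforhodamine B assay, with a stated time of 48 h, tested at 10 uM (a higher number here means more inhibition at the concentration tested (going by the name of the read-out), a lower number less inhibition), compound 1 gives 44.4%. Compound 2 `c1ccc(-c2cn3ccnc3c(-c3ccc4ncn(C5CCCCC5)c4c3)n2)cc1` carries phenyl, and in this assay compound 2 gives 54.4%. Compound 3 `COc1ccc(-c2cn3ccnc3c(-c3ccc4ncn(C5CCCCC5)c4c3)n2)cc1` carries 4-methoxyphenyl, and in this assay compound 3 gives 97.4%, the highest of the three; it stands a number 43 percentage points higher from compound 2 to compound 3 (beyond the scatter) and a number 53 percentage points higher from compound 1 to compound 3 (beyond the scatter), both beyond the scatter, while the step of a number 10 percentage points higher from compound 1 to compound 2 (within the scatter) lies within it.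

Compound 4 `c1ccc2c(-c3cn4ccnc4c(-c4ccc5ncn(C6CCCCC6)c5c4)n3)cccc2c1` has not been measured in this assay. It differs from compound 3 in one place: naphthalen-1-yl in place of 4-methoxyphenyl on an aromatic carbon. Going by the values given here, the step from compound 2 to compound 3 bears most on this change, since it shows that removing the methoxy costs a large part of the inhibition; the bigger naphthalen-1-yl has no measured precedent here. A drop of roughly a number 39.4 percentage points lower from compound 3 to compound 4 (beyond the scatter) is therefore expected, with wide uncertainty. Compound 4 is expected to give about 58%, between 30% and 88%.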

Compound 4, a percentage reported as inhibition, at one concentration (the size of the read-out at that concentration, not a potency): 10.4%
Beside the measured number, compound 4's estimate is 47.6 percentage points above it; measured number below the stated range.
By their numbers in this assay, from the lowest: compound 4; then compounds 1 and 2 (each within the scatter of the next); then compound 3.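

In this assay, this position does not simply favour a larger aromatic group: swapping phenyl for naphthalen-1-yl, which has two six-membered aromatic rings of carbon only, gives a number 44 percentage points lower from compound 2 to compound 4 (beyond the scatter), and swapping 4-methoxyphenyl for it gives a number 87 percentage points lower from compound 3 to compound 4 (beyond the scatter). Even against the bromo group the change gives a number 34 percentage points lower from compound 1 to compound 4 (beyond the scatter), so among these compounds an aromatic ring at this carbon can go with a much lower number as well as a much higher one, as compound 4 and compound 3 show. Nothing measured here accounts for this fall.

The compounds shown leave open whether the loss follows from the second ring itself or from how it is attached, which a naphthalen-2-yl group would test. They also leave open whether a hydroxy group or an amine on the phenyl ring could match the methoxy group.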